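From 3-Methylphenyl to Pyridin-3-yl at the Assay Limit

A few compounds are considered here, and "the series" means these few. Any claim that something is new, unique, unknown or untested is made for them only; others in the source may bear on it.

In an ADME assay on MRC5 cells (Homo sapiens) for cytotoxicity, read by fluorescence and resazurin assay, with a stated time of 3 days (a lower number here means a stronger inhibitor, a higher number a weaker inhibitor), compound 1 `Cc1cn(C2CCN(Cc3cncc(Oc4cccc(Cl)c4)c3)CC2)c(=O)[nH]c1=O` gives > 64000 nM as a limit of the assay. Compound 2 `Cc1cccc(Oc2cccc(CN3CCC(n4cc(C)c(=O)[nH]c4=O)CC3)c2)c1` gives > 64000 nM as a limit too, so it has no number of its own and stands with compound 1 at the limit of > 64000 nM in this assay, at which 2 of the 2 values shown sit, on this measure. Compound 3 `Cc1cn(C2CCN(Cc3cccc(Oc4cccnc4)c3)CC2)c(=O)[nH]c1=O` has pyridin-3-yl in place of 3-methylphenyl on an oxygen on an aromatic ring as its difference from compound 2. For the measured compounds named here, no measured step covers this change, so the expected step of a number no higher from compound 2 to compound 3 (the limit leaves the size open) in this assay is none beyond the scatter. For compound 3 the estimated value is 64000 nM with an expected range from 32000 nM to 128000 nM and a reading at the limit is likely.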

Compound 3, half-maximal inhibitory concentration: > 64000 nM
Compound 3: only a limit was reported (the forecaster's own chance of this, stated with the estimate: 85%); the middle value lies on the limit itself.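

Compound 2 and compound 3 both stand as limits in this assay, so no step can be read between them: the limit of > 64000 nM in this assay, at which 3 of the 3 values shown sit.

The compounds shown leave open what value each would have, and whether pyridin-3-yl in place of 3-methylphenyl changes it at all.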